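The compounds below may be only part of what the source reports. "The series", "measured", "known", "first", "only" and "open" are said of these compounds alone.

The compounds share one core, shown first in compound 1 `O=C1NC(=O)/C(=C/c2cn(Cc3ccccc3)c3ccccc23)N1`. In a functional assay on A549 cells (Homo sapiens) for antiproliferative activity, read by trypan blue exclusion, with a stated time of 24 h (a higher number here means a weaker inhibitor, a lower number a stronger inhibitor), compound 1 reaches only the limit of the assay, > 40000 nM. Compound 2 `Cc1ccc2c(c1)c(/C=C1\NC(=O)NC1=O)cn2Cc1ccccc1` carries a methyl on an aromatic carbon, and in this assay compound 2 gives 27700 nM, a step of an at least 1.4-fold lower number from compound 1 to compound 2 (0.15 log units; that floor lies within the scatter). Compound 3 `O=C1NC(=O)/C(=C/c2cn(Cc3ccccc3)c3ccc(Br)cc23)N1` carries a bromo on that aromatic carbon instead. In this assay compound 3 again returns only a limit, > 40000 nM. Compound 3 therefore stands at the limit of > 40000 nM in this assay, at which 2 of the 3 values shown sit. The measured steps place it as an at least 1.4-fold higher number from compound 2 to compound 3 (0.15 log units; that floor lies within the scatter), whereas the comparison a step that the two limits leave unreadable from compound 1 to compound 3. Compound 4 `COc1ccc2c(c1)c(/C=C1\NC(=O)NC1=O)cn2Cc1ccccc1` differs from compound 3 by methoxy in place of bromo on an aromatic carbon. Among the compounds with values here, no measured step involves a methoxy, so only the bromo steps bear on this change, and they show compound 3 at the limit with the one readable step staying within the scatter. The step from compound 3 to compound 4 is therefore expected to be none beyond the scatter, a number no higher from compound 3 to compound 4 (the limit leaves the size open), with a real chance that compound 4 again reports only a limit. Compound 4 is estimated at 40000 nM in this assay, within a range from 15000 nM to 100000 nM.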

Compound 4, half-maximal inhibitory concentration: > 40000 nM
Compound 4 gave a limit, no number; the forecaster's own chance of this, stated with the estimate: 60%; the middle value lies on the limit itself.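

In this assay compound 4 returns only a limit, > 40000 nM, so a methoxy on this aromatic carbon, which brings a hydrogen-bond acceptor that bromo does not, still yields no number. Within the data shown here, the only step that can be read is an at least 1.4-fold higher number from compound 2 to compound 4 (0.15 log units; that floor lies within the scatter), and the steps that join two limits cannot be read. Compound 2, with its methyl, thus remains the only compound here with a number rather than a limit, and the limit now holds most of the series: the limit of > 40000 nM in this assay, at which 3 of the 4 values shown sit.

From the compounds shown here alone, whether an amine, a carboxylic acid or a longer chain on this aromatic carbon would bring the read-out away from the limit stays open. Going by these compounds, the true gaps among compound 1, compound 3 and compound 4 also stay open, as does whether compound 2 truly differs from any of them by more than the scatter.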